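A few compounds are considered here, and "the series" means these few. Any claim that something is new, unique, unknown or untested is made for them only; others in the source may bear on it.

Compound 1 `CCCCc1ccc(-c2cc(N3CCC(CNS(N)(=O)=O)CC3)ncn2)cc1`: in a functional assay on M21 cells (Homo sapiens) for antiproliferative activity, read by sulforhodamine B assay, with a stated time of 48 h (on this read-out higher numbers stand for weaker inhibition of growth and lower numbers for stronger inhibition of growth), compound 1 gives 47200 nM.
Compound 2 `CCCCc1ccc(-c2cc(N3CCC(CCNS(N)(=O)=O)CC3)ncn2)cc1`: in this assay compound 2 gives 15100 nM.

Compound 2 stands at the lower of the two numbers. Within the data shown here, the single measured step, a 3.1-fold lower number from compound 1 to compound 2 (0.49 log units; beyond the scatter), concerns the chain on the saturated ring and not the aryl substituent. Compound 3 `NS(=O)(=O)NCCC1CCN(c2cc(-c3ccc(C(F)(F)F)cc3)ncn2)CC1` differs from compound 2 by trifluoromethyl in place of butyl on an aromatic carbon. Among the measured compounds shown here, no measured step bears on this change, so its direction is open and no step beyond the scatter is assumed. For compound 3 the expected value is 18000 nM, range 5000 nM to 70000 nM. This estimate means a step of a 1.2-fold higher number from compound 2 to compound 3 (0.08 log units; within the scatter).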

Compound 3, concentration for 50% growth inhibition: 34800 nM
For compound 3 the middle estimate is 1.9-fold (0.29 log units) below the measured one, within the range that was stated.
By their numbers in this assay, from the lowest: compound 2; then compounds 3 and 1 (each within the scatter of the next).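

In this assay trifluoromethyl in place of butyl on the aromatic carbon para to a large group gives a 2.3-fold higher number from compound 2 to compound 3 (0.36 log units; beyond the scatter) and so shows that this position, not only the chain on the saturated ring, alters the read-out. Of these two groups, butyl carries the lower number. Nothing measured here accounts for the step.

Going by these compounds, whether a longer chain, an amine or a carboxylic acid at this aromatic carbon would lower the number further remains open. So does whether the butyl to trifluoromethyl step holds with the chain of compound 1.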